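Phenyl for furan-2-yl: a second instance on a new core

The source may hold more compounds than are shown below. What is called first, only, known or untested is meant among the compounds shown, and "the series" means these compounds.

Compound 2 `Oc1cccc(-c2cc(-c3ccc(Cl)cc3)nc(-c3ccco3)c2)c1` and compound 1 `Oc1cccc(-c2cc(-c3ccccc3)nc(-c3ccc(Cl)cc3)c2)c1` share one core; in a functional assay on HCT-15 cells (Homo sapiens) for cytotoxicity, read by CCK-8 assay and cell counting, with a stated time of 2 days (on this read-out lower numbers stand for stronger inhibition and higher numbers for weaker inhibition), compound 2 gives 10200 nM and compound 1 gives 8110 nM, a step of a 1.3-fold lower number from compound 2 to compound 1 (0.10 log units; within the scatter). The change behind it is phenyl in place of furan-2-yl on an aromatic carbon. Compound 3 `Oc1ccc(-c2cc(-c3cccc(Cl)c3)nc(-c3ccco3)c2)cc1` carries the same atoms as compound 2 joined differently; the difference between the two cores is not broken down here. In this assay compound 3 gives 8020 nM, which sits within the scatter of both compound 1 and compound 2, so no order among the three is claimed.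

Compound 4 `Oc1ccc(-c2cc(-c3ccccc3)nc(-c3cccc(Cl)c3)c2)cc1` is not yet measured. It differs from compound 3 by phenyl in place of furan-2-yl on an aromatic carbon. This is the same kind of change as from compound 2 to compound 1, but the surroundings differ: there the site was meta to a 3-hydroxyphenyl group and meta to a 4-chlorophenyl group, here it is meta to a 3-chlorophenyl group and meta to a 4-hydroxyphenyl group. In this assay the expected step is a 1.2-fold lower number from compound 3 to compound 4 (0.09 log units; within the scatter), set beside the earlier step because a 1.3-fold lower number from compound 2 to compound 1 (0.10 log units; within the scatter) was within the scatter. Compound 4 is estimated at 6500 nM, between 3200 nM and 13000 nM.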

Compound 4, half-maximal inhibitory concentration: 6100 nM
The estimate for compound 4 lay 1.1-fold (0.03 log units) above the measured number; low and high end bracket the measured number.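

In this assay, phenyl in place of furan-2-yl on the aromatic carbon next to the ring nitrogen gives a 1.3-fold lower number from compound 3 to compound 4 (0.12 log units; within the scatter). Set beside the first instance, the change reads the same on the two cores: the same change on two cores in this assay, a 1.3-fold lower number (0.10 log units; within the scatter) from compound 2 to compound 1 and a 1.3-fold lower number (0.12 log units; within the scatter) from compound 3 to compound 4, 1.0-fold (0.02 log units) apart, within the scatter of two such steps This shows that the exchange carries from the core of compound 2 to the core of compound 3 with no step beyond the scatter on either and no difference between them, but it does not show that either ring gives a real change in the number, and two cores say nothing about any other core in the series.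

On these data alone, only furan-2-yl and phenyl have been compared at this site, so it remains open whether a phenyl ring bearing an amine or a carboxylic acid, or a saturated ring such as piperidine, would move the number beyond the scatter. Also open, as far as these compounds go, is whether the step stays this small when the hydroxyl group gives way to a methoxy group.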